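A few compounds are considered here, and "the series" means these few. Any claim that something is new, unique, unknown or untested is made for them only; others in the source may bear on it.

Compound 1 `N#CC1=C(N)Oc2c(c3nc4ccccc4nc3c3ccccc23)C12C(=O)N(Cc1cnnn1-c1cccc(S(N)(=O)=O)c1)c1ccccc12` — in a functional assay on HCT-116 cells (Homo sapiens) for antiproliferative activity, read by MTT assay, with a stated time of 48 h (on this read-out higher numbers stand for weaker inhibition and lower numbers for stronger inhibition), compound 1 gives 11300 nM.
Compound 2 `Cc1cc(C)cc(-n2nncc2CN2C(=O)C3(C(C#N)=C(N)Oc4c3c3nc5ccccc5nc3c3ccccc43)c3ccccc32)c1` — in this assay compound 2 gives > 50000 nM, which is a limit of the assay.
Compound 3 `N#CC1=C(N)Oc2c(N)cc3nc4ccccc4nc3c2C12C(=O)N(Cc1cnnn1-c1ccccc1Cl)c1ccccc12` — in this assay compound 3 gives > 50000 nM, again a limit of the assay.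

The three compounds share a core and differ in the aryl group on the triazole nitrogen or in the amino group on the core. Compound 3 stands at the limit of > 50000 nM in this assay, at which 2 of the 3 values shown sit, so no number is known for it, only that it inhibits less strongly than the limit would show.

Compound 4 `COc1ccccc1-n1nncc1CN1C(=O)C2(C(C#N)=C(N)Oc3c(N)cc4nc5ccccc5nc4c32)c2ccccc21` differs from compound 3 in one place: methoxy in place of chloro on an aromatic carbon. Among the measured compounds shown here, the only measured step that bears on changing this aryl group is an at least 4.4-fold higher number from compound 1 to compound 2 (0.64 log units; beyond the scatter), which went toward weaker inhibition and did not stay within the scatter. That step moved a different group at a different place, so it can only suggest that this aryl group matters. Because compound 3 already sits at the limit of > 50000 nM in this assay, at which 2 of the 3 values shown sit, there is little room for a weaker number to show, and the step of a number no higher from compound 3 to compound 4 (the limit leaves the size open) is expected to leave compound 4 at or near that limit. Compound 4 is therefore estimated at 50000 nM, with a range from 15000 nM to 150000 nM.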

Compound 4, half-maximal inhibitory concentration: > 50000 nM
Compound 4: a limit, no number; the forecaster's own chance of this, stated with the estimate: 70%; the middle value sits exactly at the limit.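

Compound 3 and compound 4 both sit at a limit in this assay and not at a number, so no step can be read between them. On these data alone, what stays open is how far each compound lies past that limit, and whether 2-methoxyphenyl in place of 2-chlorophenyl changes the result at all.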